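The source may report more compounds than this note shows. Statements on the series, on what has been measured and on what is new or still open speak of the compounds shown alone.

Compound 1 `O=C(COc1ccc(Oc2ccccc2)cc1)Cn1ncc2cc(C(=O)O)ccc21` gives 55 nM in an assay on microsomes from brain for inhibition of Fatty-acid amide hydrolase 1 (Rattus norvegicus), read by fluorescence and HPLC, with a stated time of 45 min (a lower number here means a stronger inhibitor, a higher number a weaker inhibitor), the lowest of the two numbers measured; compound 2 `COC(=O)Nc1ccc2c(cnn2CC(=O)COc2ccc(Oc3ccccc3)cc2)c1` gives 4000 nM. Within the data shown here, the one measured step, a 73-fold higher number from compound 1 to compound 2 (1.86 log units; beyond the scatter), shows a large loss when the carboxy group is replaced. Compound 3 `O=C(COc1ccc(Oc2ccccc2)cc1)Cn1ncc2cc(C(=O)NS(=O)(=O)c3ccccc3)ccc21` differs from compound 1 by (phenylsulfonyl)amino in place of hydroxy on a carbonyl carbon; the carbonyl stays and one hydrogen-bond donor remains. Among the measured compounds shown here, since the only measured step concerns a different replacement, the outcome is uncertain, but a weakening smaller than that step is expected: a 2.7-fold higher number from compound 1 to compound 3 (0.44 log units; beyond the scatter). Compound 3 is therefore estimated at 150 nM, within 30 nM to 700 nM.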

Compound 3, half-maximal inhibitory concentration: 4700 nM
Compound 3: the middle estimate sits 31-fold (1.50 log units) below what was measured; measured number outside the range, above it.
By their numbers in this assay, from the lowest: compound 1; then compounds 2 and 3 (each within the scatter of the next).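

Replacing carboxy with (phenylsulfonyl)carbamoyl gives an 85-fold higher number from compound 1 to compound 3 (1.93 log units; beyond the scatter), so keeping the carbonyl and a hydrogen-bond donor at this place is not enough to hold the low number of compound 1. Two quite different replacements of carboxy now end up level, with a 1.2-fold higher number from compound 2 to compound 3 (0.07 log units; within the scatter), and only the compound with the carboxy group keeps its low number. No measurement shown here explains this loss.

Still open, as far as these compounds go, is how a methyl ester, a plain carbamoyl or a (methylsulfonyl)carbamoyl group would fare on this carbonyl carbon.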